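From cyclopropyl to methoxy: one cytotoxicity step

The compounds below may be only part of what the source reports. "The series", "measured", "known", "first", "only" and "open" are said of these compounds alone.

- compound 1 `O=c1c(C2CC2)cc(-c2ccc(F)nc2F)nn1Cc1ccc(Cl)cc1`: 39800 nM
- compound 2 `COCCNc1ccc(-c2nn(Cc3ccc(C#N)cc3)c(=O)c3ccccc23)c(F)n1`: > 100000 nM
- compound 3 `Cc1cc(-c2ccc(F)nc2F)cn(Cc2ccc(Cl)cc2)c1=O`: 90800 nM

In an ADME assay on HepG2 2.2.15 cells (Homo sapiens) for cytotoxicity, read by MTT assay, with a stated time of 8 days (on this read-out higher numbers stand for lower toxicity in this test and lower numbers for higher toxicity in this test), compound 1 gives the lowest number shown, 39800 nM. Compound 3 reads higher at 90800 nM, a gap beyond the scatter. Compound 2 gives > 100000 nM, which is a limit of the assay and not a number.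

Compound 4 `COc1cc(-c2ccc(F)nc2F)nn(Cc2ccc(Cl)cc2)c1=O` has methoxy in place of cyclopropyl on an aromatic carbon. Among the measured compounds shown here, no measured pair shows this change, so the expectation is loose. Compound 3 at 90800 nM suggests that a related compound can read higher in this assay. A modest rise is expected, estimated as a 1.5-fold higher number from compound 1 to compound 4 (0.18 log units; within the scatter), and it may not exceed the scatter. For compound 4 the estimate is 60000 nM, with an expected range of 28000 nM to 100000 nM.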

Compound 4, half-maximal cytotoxic concentration: 92200 nM
The estimate for compound 4 lay 1.5-fold (0.19 log units) below the measured number; the range from low to high includes it.
By their numbers in this assay, from the lowest: compound 1; then compounds 3 and 4 (each within the scatter of the next). At a limit, above all of these: compound 2.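

In this assay, among the compounds shown here, this pair gives the first direct reading of a change at this position, the aromatic carbon opposite the ring nitrogen: methoxy in place of cyclopropyl gives a 2.3-fold higher number from compound 1 to compound 4 (0.36 log units; beyond the scatter). The change removes a three-membered ring and adds a hydrogen-bond acceptor, and a single pair cannot separate these two differences. Further rises on this scale would soon meet its end: the limit of > 100000 nM in this assay, at which 1 of the 4 values shown sits.

An amine or a longer chain such as ethoxy at this position would help show whether the step depends on the oxygen or on the loss of the ring. From the compounds shown here alone, whether the same change gives a similar step on another core also stays open.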